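A few compounds are considered here, and "the series" means these few. Any claim that something is new, unique, unknown or untested is made for them only; others in the source may bear on it.

Three compounds have been measured in a functional assay on B16-F10 cells (Mus musculus) for inhibition, tested at 5 uM; a lower number here means less inhibition, a higher number more inhibition at the concentration tested (going by the name of the read-out):
compound 1 `CC(/C=C/C1=CCCCC1(C)C)=C\C=C\C(C)=C\COC(=O)c1cccc(O)c1O` gives 18.6%;
compound 2 `COc1cc(O)c(C(=O)OC/C=C(C)/C=C/C=C(C)/C=C/C2=CCCCC2(C)C)c(O)c1` gives 9.5%;
compound 3 `COc1cccc(C(=O)OC/C=C(C)/C=C/C=C(C)/C=C/C2=CCCCC2(C)C)c1O` gives 16.2%.

Compound 1 holds the highest of these three numbers, yet the others sit close to it: the step of a number 9.1 percentage points lower from compound 1 to compound 2 (within the scatter) and the step of a number 2.4 percentage points lower from compound 1 to compound 3 (within the scatter) both lie within the scatter, as does a number 6.7 percentage points higher from compound 2 to compound 3 (within the scatter). The three compounds share the same core and differ only in what sits on the aromatic ring attached to the carbonyl carbon. Compound 4 `CC(/C=C/C1=CCCCC1(C)C)=C\C=C\C(C)=C\COC(=O)c1c(O)cccc1O` has the same atoms as compound 1, joined differently: 2,6-dihydroxyphenyl in place of 2,3-dihydroxyphenyl on a carbonyl carbon. Every measured step that altered this ring left the read-out essentially unchanged, so no step beyond the scatter is expected in this assay. Compound 4 is therefore estimated at 18%, between 8% and 28%, an expected step of a number 0.6 percentage points lower from compound 1 to compound 4 (within the scatter).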

Compound 4, a percentage reported as inhibition, at one concentration (the size of the read-out at that concentration, not a potency): 12.7%
Beside the measured number, compound 4's estimate is 5.3 percentage points above it, within the range that was stated.
By their numbers in this assay, from the lowest: compounds 2, 4, 3 and 1 (each within the scatter of the next).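

In this assay, 2,6-dihydroxyphenyl in place of 2,3-dihydroxyphenyl on a carbonyl carbon gives a number 5.9 percentage points lower from compound 1 to compound 4 (within the scatter) and so shows that rearranging the two hydroxy groups on this ring has no effect that can be told from the scatter. Likewise, a number 3.5 percentage points lower from compound 3 to compound 4 (within the scatter) and a number 3.2 percentage points higher from compound 2 to compound 4 (within the scatter) both stay inside the usual scatter, so this ring has not yet given a clear difference. Nothing available bears on why these numbers fall as they do.

Still open, as far as these compounds go, is whether an amine or a carboxylic acid on this ring would give a step beyond the scatter.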